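The source may report more compounds than this note shows. Statements on the series, on what has been measured and on what is new or still open speak of the compounds shown alone.

Compound 1 `COC(=O)c1ccc(NCc2cncn2Cc2ccccc2C)cc1-c1ccccc1` gives 10000 nM in a toxicity assay on NIH3T3 cells (Mus musculus) for cytotoxicity, read by resazurin assay; a higher number here means that more compound is needed for the effect, a lower number that less compound is needed.
Compound 2 `COC(=O)c1ccc(NCc2cncn2Cc2ccccc2OC)cc1-c1ccccc1` gives "not determined" (no result reported) in this assay.

Compound 2 therefore stands without a number in this assay; the only measured point in this series is compound 1, whose value in this assay is 10000 nM. Compound 3 `COC(=O)c1ccc(NCc2cncn2Cc2ccc(F)cc2F)cc1-c1ccccc1` has not yet been measured in this assay. It differs from compound 2 in one place: 2,4-difluorophenyl in place of 2-methoxyphenyl on a saturated chain carbon bound to an aromatic nitrogen. Going by the values given here, since compound 2 carries no number, no step from compound 2 to compound 3 can be read off, and the expectation for compound 3 must rest on compound 1 alone.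

Compound 3 shares the whole core of compound 1 and changes only the group on the saturated chain carbon bound to the aromatic nitrogen, so the expectation in this assay is for a step of no size beyond the scatter in either direction. On that basis compound 3 is expected to give about 10000 nM in this assay, with the likely range running from 4000 nM to 25000 nM, because compound 1 gives 10000 nM.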

Compound 3, half-maximal effective concentration: > 1000 nM
Compound 3: only a limit was reported (the forecaster's own chance of this, stated with the estimate: 40%); the middle value does not contradict the limit.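

For compound 3, the result in this assay is > 1000 nM, which is a limit and not a number. Going by these compounds alone, no step can therefore be read from compound 1 or compound 2 to compound 3: the limit of > 1000 nM in this assay, at which 1 of the 3 values shown sits. The compounds shown leave open how 2,4-difluorophenyl compares with 2-methylphenyl or 2-methoxyphenyl in this assay.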